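Predicting Cell Tolerance of a Methoxy Analogue

The source may hold more compounds than are shown below. What is called first, only, known or untested is meant among the compounds shown, and "the series" means these compounds.

Of the compounds shown here, three sharing a common core have been tested in an ADME assay on MT4 cells (Homo sapiens) for cytotoxicity, read by MTT assay, with a stated time of 4 days; a lower number here means that less compound is tolerated, a higher number that more compound is tolerated. Compound 1 `CC(=O)Nc1ccc2oc(-c3ccccc3)c(O)c(=O)c2c1` gives 64700 nM in this assay. Compound 2 `COc1cccc(-c2oc3ccc(NC(C)=O)cc3c(=O)c2O)c1` carries one more group, (methoxy in place of hydrogen on an aromatic carbon), and in this assay compound 2 gives 33300 nM. The step between them is a 1.9-fold lower number from compound 1 to compound 2 (0.29 log units; within the scatter). Compound 3 `Nc1ccc2oc(-c3ccccc3)c(O)c(=O)c2c1` differs from compound 1 at the core by hydrogen in place of acetyl on a nitrogen on an aromatic ring, and in this assay compound 3 gives 217000 nM, the highest of the three numbers. The step from the first to the third compound is a 3.4-fold higher number from compound 1 to compound 3 (0.53 log units; beyond the scatter).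

Compound 4 `COc1cccc(-c2oc3ccc(N)cc3c(=O)c2O)c1` has not yet been measured. It differs from compound 3 by methoxy in place of hydrogen on an aromatic carbon. This is the same change that was made between compound 1 and compound 2, with the place described in the same words, and it occurs twice among the compounds shown. The step it made between compound 1 and compound 2 stayed within the scatter of repeated measurements.

On the assumption that the same change behaves the same way on the core of compound 3, the step from compound 3 to compound 4 in this assay is expected to be a 1.9-fold lower number from compound 3 to compound 4 (0.28 log units; within the scatter). Among the measured compounds shown here, this expectation rests only on compound 1 and compound 2, because a 1.9-fold lower number from compound 1 to compound 2 (0.29 log units; within the scatter) is the single earlier example of this change. Compound 4 is therefore estimated at 115000 nM, with a plausible range from 50000 nM to 260000 nM.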

Compound 4, half-maximal cytotoxic concentration: 40800 nM
Beside the measured number, compound 4's estimate is 2.8-fold (0.45 log units) above it, and the stated range ends above it.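

In this assay, placing methoxy on the core of compound 3 gives a 5.3-fold lower number from compound 3 to compound 4 (0.73 log units; beyond the scatter), and this step does not match the one seen for the same change on the core of compound 1: the same change on two cores in this assay, a 1.9-fold lower number (0.29 log units; within the scatter) from compound 1 to compound 2 and a 5.3-fold lower number (0.73 log units; beyond the scatter) from compound 3 to compound 4, 2.7-fold (0.44 log units) apart, beyond the scatter of two such steps Read the other way, hydrogen in place of acetyl on the nitrogen gives a 1.2-fold higher number from compound 2 to compound 4 (0.09 log units; within the scatter), so this second change also depends on the core that carries it: the same change on two cores in this assay, a 3.4-fold higher number (0.53 log units; beyond the scatter) from compound 1 to compound 3 and a 1.2-fold higher number (0.09 log units; within the scatter) from compound 2 to compound 4, 2.7-fold (0.44 log units) apart, beyond the scatter of two such steps These four compounds show that a step measured on one core cannot simply be carried over to another core in this series, but they do not show why the steps differ, and two cores are too few to say how either change would behave on a third.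

On these data alone, it stays open whether a chlorine or an ethoxy group in the place of the methoxy would also give a step that depends on the core, and whether a longer chain on the nitrogen, such as propanoyl in place of acetyl, would behave as acetyl does. As far as these compounds go, how these same pairs of compounds behave in other cell types also stays open.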